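The source may report more compounds than this note shows. Statements on the series, on what has been measured and on what is new or still open speak of the compounds shown alone.

Measured compounds: Compound 1, `Cc1ccc(NC(=O)c2cccc(C(F)(F)F)c2)cc1NC(=O)c1cnc(Nc2ccc(C)c([N+](=O)[O-])c2)nc1`, in an ADME assay on BaF3 cells (Mus musculus) for antiproliferative activity, read by CellTiter-Glo and CCK-8 assay, with a stated time of 72 h (on this read-out higher numbers stand for weaker inhibition of growth and lower numbers for stronger inhibition of growth), gives 8700 nM. Compound 2, `CNc1nc(Nc2ccc(C)c(N)c2)ncc1C(=O)Nc1cc(NC(=O)c2cccc(C(F)(F)F)c2)ccc1C`, in this assay gives only the limit > 10000 nM. Compound 3, `Cc1ccc(Nc2ncc(C(=O)Nc3cc(NC(=O)c4cccc(C(F)(F)F)c4)ccc3C)c(N(C)C)n2)cc1N`, in this assay gives only the limit > 10000 nM.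

Going by the values given here, compound 3 therefore stands at the limit of this assay, not at a number, and compound 1 is the only compound of the three with a measured value. Among the compounds with values here, the one step among the measured compounds, a step that the two limits leave unreadable from compound 2 to compound 3, adds a methyl to a nitrogen on an aromatic ring, and its size is hidden by the limit of > 10000 nM in this assay, at which 2 of the 3 values shown sit.

Compound 4, `Cc1ccc(Nc2ncc(C(=O)Nc3cc(NC(=O)c4cccc(C(F)(F)F)c4)ccc3C)cn2)cc1N`, differs from compound 3 in one place: hydrogen in place of dimethylamino on an aromatic carbon. Within the data shown here, no measured step among the three compounds removes a dimethylamino group, so the size of this step is not readable from them. Compound 1, which likewise carries no dimethylamino group, gives 8700 nM.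

Compound 4 is therefore expected to lie near that value, with the step of an at least 1.2-fold lower number from compound 3 to compound 4 (0.09 log units; that floor lies within the scatter) from the limit of compound 3 unknown in size, and the estimate for compound 4 in this assay is 8000 nM, ranging from 2000 nM to 30000 nM.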

Compound 4, concentration for 50% growth inhibition: > 10000 nM
Compound 4 ended at the assay's limit; the forecaster's own chance of this, stated with the estimate: 40%; middle value at least 1.2-fold (0.09 log units) away from the limit.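

In this assay compound 4 gives > 10000 nM, which is a limit and not a number. Hydrogen on this aromatic carbon, next to the ring nitrogen, thus ends at the same limit as methylamino in compound 2 and dimethylamino in compound 3, so none of the three groups gives a number at this position and the steps among these compounds cannot be read: the limit of > 10000 nM in this assay, at which 3 of the 4 values shown sit. The only step that can be read is an at least 1.1-fold higher number from compound 1 to compound 4 (0.06 log units; that floor lies within the scatter), with amino in place of nitro on an aromatic carbon, and it sets no order between the two.

What a methoxy group or a chlorine on this carbon would give in this assay stays open, so the compounds shown do not tell whether any group at this position can bring the read-out to a number while the amino group is kept. Also open is whether nitro in place of amino would give a number with methylamino or dimethylamino on this carbon, as the only nitro compound shown carries hydrogen there.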